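A few compounds are considered here, and "the series" means these few. Any claim that something is new, unique, unknown or untested is made for them only; others in the source may bear on it.

Compound 1 `COc1cc(NC(C)CCCNC(=O)NN)c2ncccc2c1`: >= 250000 nM (a limit of the assay, not a number)
Compound 2 `COc1cc(NC(C)CCCNC(=O)NNC(=O)NCCO)c2ncccc2c1`: 196000 nM

Both compounds were tested in a functional assay on HeLa cells (Homo sapiens) for inhibition, read by MTT assay, with a stated time of 4 days; a lower number here means a stronger inhibitor, a higher number a weaker inhibitor. In this assay, for the measured compounds named here, compound 2 gives 196000 nM, the only true number available. Compound 1 stands at a limit, recorded as the limit of >= 250000 nM in this assay, at which 1 of the 2 values shown sits.

Compound 3 `COc1cc(NC(C)CCCNC(=O)NNC(=O)NCCCO)c2ncccc2c1` differs from compound 2 by hydroxymethyl in place of hydroxy on a saturated chain carbon, two bonds along the chain from an amide-type nitrogen. In words, hydroxymethyl takes the place of hydroxy on a saturated chain carbon, two bonds along the chain from an amide-type nitrogen, so 2-hydroxyethyl becomes 3-hydroxypropyl.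

Going by the values given here, only one measured step bears on this change: an at least 1.2-fold lower number from compound 1 to compound 2 (0.10 log units; that floor lies within the scatter). Among the compounds with values here, that step places (2-hydroxyethyl)carbamoyl on an amine nitrogen, and no measured pair varies the chain length. No shift beyond the scatter is therefore expected. The expected change is a 1.2-fold lower number from compound 2 to compound 3 (0.06 log units; within the scatter). The estimate for compound 3 is 170000 nM, with an expected range from 80000 nM to 250000 nM.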

Compound 3, half-maximal inhibitory concentration: > 250000 nM
Compound 3: no number, only a limit; the forecaster's own chance of this, stated with the estimate: 25%; at least 1.4-fold (0.16 log units) between middle value and limit.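

In this assay compound 3, which carries 3-hydroxypropyl, gives no number, only a limit of the assay: the limit of > 250000 nM in this assay, at which 1 of the 3 values shown sits.

The change from 2-hydroxyethyl to 3-hydroxypropyl reads as an at least 1.2-fold higher number from compound 2 to compound 3 (0.10 log units; that floor lies within the scatter), so this first look at chain length here shows no gain in inhibition, and the true size of the step stays hidden behind the limit. Compound 1 and compound 3 both stand at limits, and the step between them cannot be read.

Still open, from the compounds shown here alone, is whether an amine or a carboxylic acid in place of the hydroxy, or a longer chain, would give a clearly lower number than compound 2 at 196000 nM. Going by these compounds, how far compound 3 lies past its limit also remains unknown.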